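Benzyl Ester Step on a Methylated Urea Core

The compounds below may be only part of what the source reports. "The series", "measured", "known", "first", "only" and "open" are said of these compounds alone.

Measured compounds:
Compound 1 `CC1=C(C(=O)OCc2ccccc2)C(c2ccco2)NC(=O)N1`, 3%
Compound 2 `CC1=C(C(=O)OC(C)(C)C)C(c2ccco2)NC(=S)N1`, 9%
Compound 3 `CC1=C(C(=O)OCC(C)C)C(c2ccco2)NC(=O)N1C`, 23%

In an assay on membranes from HeLa cells for displacement of a labelled ligand from adenosine receptor A3 (Homo sapiens), read by scintillation counting, with a stated time of 180 min, tested at 1 uM (on this read-out lower numbers stand for less inhibition and higher numbers for more inhibition at the one concentration tested (going by the name of the read-out)), compound 3 gives 23%, the highest of the three numbers; its gap to compound 2, and the still wider one to compound 1, both lie beyond the usual scatter of this measurement.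

Compound 4 `CC1=C(C(=O)OCc2ccccc2)C(c2ccco2)NC(=O)N1C` has not yet been tested. It differs from compound 3 in one place: phenyl in place of isopropyl on a saturated chain carbon bound to an oxygen next to a carbonyl group. The same ester group is already present in compound 1, which gives 3% in this assay, although compound 1 also lacks the methyl on the ring nitrogen that compound 3 and compound 4 share, so the two values cannot be set against each other directly.

For the measured compounds named here, no measured pair shows this exact change, so the expectation is cautious. Compound 4 is expected to give an estimated 15%, with a likely range from 2% to 35%. The expected step of a number 8 percentage points lower from compound 3 to compound 4 (within the scatter) is a modest fall, at the edge of the scatter, leaning lower because compound 1 with the same ester gives only 3%.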

Compound 4, a percentage reported as inhibition, at one concentration (the size of the read-out at that concentration, not a potency): 11%
For compound 4 the middle estimate is 4 percentage points above the measured one; measured number inside the range.
By their numbers in this assay, from the lowest: compounds 1, 2 and 4 (each within the scatter of the next); then compound 3.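

In this assay, the change from isobutyl to benzyl, with phenyl in place of isopropyl on a saturated chain carbon bound to an oxygen next to a carbonyl group, gives a number 12 percentage points lower from compound 3 to compound 4 (beyond the scatter), the first sign that this ester group affects the read-out when the methyl on the ring nitrogen is held constant. With the benzyl ester kept, methyl in place of hydrogen on an amide-type nitrogen in a ring gives a number 8 percentage points higher from compound 1 to compound 4 (within the scatter), so this pair shows no clear effect of that methyl. No measured evidence here explains either step.

For the compounds shown here, the methyl step is seen only with the benzyl ester, so its size with the isobutyl ester stays open. Also open, going by these compounds, is how a longer chain, or an amine in place of phenyl on that same saturated chain carbon, would compare with these esters.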